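Two Limits and a Compound Still to Be Tested

This account rests on a few compounds, and the source may have more. Where it says the series, first, only, none or still open, it means among the compounds named here.

The two measured compounds share one core. Compound 1 `COc1ccc(CSc2nnc(-c3cc([N+](=O)[O-])cc([N+](=O)[O-])c3)n2C)cc1` carries a (4-methoxybenzyl)sulfanyl group and a methyl on that core, whereas compound 2 `CCCCCCCCSc1nnc(-c2cc([N+](=O)[O-])cc([N+](=O)[O-])c2)n1Cc1ccccc1` carries an octylsulfanyl group and a benzyl. In an ADME assay on HepG2 cells (Homo sapiens) for cytotoxicity, with a stated time of 48 h (on this read-out lower numbers stand for stronger inhibition and higher numbers for weaker inhibition), compound 1 reaches only the limit of the assay, > 30000 nM. Compound 2 likewise gives only a limit in this assay, > 30000 nM. Compound 2 therefore cannot be placed in any order among the numbers shown, since the limit of > 30000 nM in this assay, at which 2 of the 2 values shown sit, describes every value that exists so far; no step between measured compounds can be drawn.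

Compound 3 `COc1ccc(CSc2nnc(-c3cc([N+](=O)[O-])cc([N+](=O)[O-])c3)n2Cc2ccccc2)cc1` is not yet measured. It differs from compound 2 by 4-methoxyphenyl in place of heptyl on a saturated chain carbon bound to a sulfur, so that the chain of compound 2 gives way to the group that compound 1 already carries. With both neighbours at the limit, no change beyond the scatter is expected in this assay: the expected step is a step that the limit leaves unreadable from compound 2 to compound 3, with no direction. Compound 3 is thus estimated at 50000 nM, within 20000 nM to 200000 nM, and will most probably again be reported only as a limit.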

Compound 3, half-maximal inhibitory concentration: > 30000 nM
Compound 3: no number, only a limit; the forecaster's own chance of this, stated with the estimate: 85%; the middle value is on the limit's open side.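

Compound 3 also gives only a limit, so neither the step from compound 2 to compound 3 nor the step from compound 1 to compound 3 can be read, and all three compounds share one limit: the limit of > 30000 nM in this assay, at which 3 of the 3 values shown sit.

The compounds shown leave open how far any of them lies beyond that limit, and whether either change alters the read-out at all.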